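Moving a Fluorine Around the Ring: Compound 4 Expected

The source may hold more compounds than are shown below. What is called first, only, known or untested is meant among the compounds shown, and "the series" means these compounds.

Measured compounds:
- compound 1, `COc1cc2c(Oc3ccc(NC(=O)c4nn(-c5ccccc5F)c(=O)c5ccccc45)cc3F)ccnc2cc1OCCCN1CCCC1`: 230 nM
- compound 2, `COc1cc2c(Oc3ccc(NC(=O)c4nn(-c5ccccc5)c(=O)c5ccccc45)cc3F)ccnc2cc1OCCCN1CCN(C)CC1`: 450 nM
- compound 3, `COc1cc2c(Oc3ccc(NC(=O)c4nn(-c5ccc(F)cc5)c(=O)c5ccccc45)cc3F)ccnc2cc1OCCCN1CCN(C)CC1`: 91 nM

Of the compounds shown here, three have been tested in a functional assay on NCI-H460 cells (Homo sapiens) for cytotoxicity, read by MTT assay, with a stated time of 72 h; on this read-out higher numbers stand for weaker inhibition and lower numbers for stronger inhibition. Compound 3 gives the lowest number of the three; compound 1 sits above it and compound 2 furthest away. Compound 4, `COc1cc2c(Oc3ccc(NC(=O)c4nn(-c5ccccc5F)c(=O)c5ccccc45)cc3F)ccnc2cc1OCCCN1CCN(C)CC1`, has not yet been measured. It differs from compound 3 in one place, (2-fluorophenyl in place of 4-fluorophenyl on an aromatic nitrogen), so the same atoms are present but the fluorine sits at a different position of the ring attached to the core nitrogen.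

Within the data shown here, one measured step bears on this region: a 4.9-fold lower number from compound 2 to compound 3 (0.69 log units; beyond the scatter), showing that placing a fluorine on this ring mattered. Compound 1 already carries the 2-fluorophenyl group, with a different tail, and gives 230 nM, a higher number than compound 3. Taken together, compound 4 is expected to land between compound 2 and compound 3, most likely nearer compound 1, so a step of a 2.2-fold higher number from compound 3 to compound 4 (0.34 log units; beyond the scatter) is expected. The estimate for compound 4 in this assay is 200 nM, with a likely range from 80 nM to 500 nM.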

Compound 4, half-maximal inhibitory concentration: 230 nM
For compound 4 the middle estimate is 1.2-fold (0.06 log units) below the measured one; measured number inside the range.
By their numbers in this assay, from the lowest: compound 3; then compounds 1, 4 and 2 (each within the scatter of the next).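

Within this assay the place of the fluorine on the ring counts: 2-fluorophenyl in place of 4-fluorophenyl gives a 2.5-fold higher number from compound 3 to compound 4 (0.40 log units; beyond the scatter) even though the atoms are the same. The earlier gain of a 4.9-fold lower number from compound 2 to compound 3 (0.69 log units; beyond the scatter) therefore belongs to 4-fluorophenyl, since fluoro in place of hydrogen in the 2-fluorophenyl compound gives only a 2.0-fold lower number from compound 2 to compound 4 (0.29 log units; within the scatter) and so stays inside the usual scatter. In this one pair, 4-methylpiperazin-1-yl in place of pyrrolidin-1-yl on the chain gives no change at the digits printed from compound 1 to compound 4 (within the scatter) and the tail makes no visible difference.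

Nothing available explains why the place of the fluorine matters. The compounds shown also leave open how 3-fluorophenyl or 4-chlorophenyl on the same aromatic nitrogen would compare, and whether the tail swap would also make no difference with 4-fluorophenyl.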